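This account rests on a few compounds, and the source may have more. Where it says the series, first, only, none or still open, it means among the compounds named here.

Going by the values given here, in a functional assay on HepG2 cells (Homo sapiens) for antiproliferative activity, read by MTT assay, with a stated time of 24 h (on this read-out lower numbers stand for stronger inhibition and higher numbers for weaker inhibition), compound 3 `COc1ccc(C(=O)/C=C/c2ccc([N+](=O)[O-])cc2)c2c1C=CC(C)(C)O2` is the only member of this small series to give an actual number, 2610 nM. Compound 1 `COc1cccc(/C=C/C(=O)c2ccc(OC)c3c2OC(C)(C)C=C3)c1` gives only a limit of the assay, > 10000 nM. Compound 2 `COc1ccc(C(=O)/C=C/c2cccc(F)c2)c2c1C=CC(C)(C)O2` likewise gives only a limit, > 10000 nM. The weak end of the series is therefore marked by the limit of > 10000 nM in this assay, at which 2 of the 3 values shown sit.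

Compound 4 `COc1ccc(C(=O)/C=C/c2ccccc2)c2c1C=CC(C)(C)O2` differs from compound 3 as follows: hydrogen in place of nitro on an aromatic carbon. In words, it has hydrogen in place of nitro on an aromatic carbon, para to a large group, so that 4-nitrophenyl becomes phenyl.

Among the compounds with values here, two measured steps bear on this change. Putting 4-nitrophenyl in place of 3-methoxyphenyl gave an at least 3.8-fold lower number from compound 1 to compound 3 (0.58 log units; beyond the scatter), and putting it in place of 3-fluorophenyl gave an at least 3.8-fold lower number from compound 2 to compound 3 (0.58 log units; beyond the scatter). Both sizes are minimums, and neither step starts from an unsubstituted phenyl, so they guide the estimate only indirectly. The remaining step, a step that the two limits leave unreadable from compound 1 to compound 2, adds nothing on size.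

Losing the nitro group should therefore reverse at least part of that gain, moving the number upward. The expected change is a 3.4-fold higher number from compound 3 to compound 4 (0.54 log units; beyond the scatter). For compound 4 the estimate is 9000 nM, with an expected range from 3500 nM to 25000 nM, and a report of only a limit would not be surprising.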

Compound 4, half-maximal inhibitory concentration: > 10000 nM
Compound 4: only a limit was reported; the forecaster's own chance of this, stated with the estimate: 55%; middle value at least 1.1-fold (0.04 log units) away from the limit.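

With the nitro group gone and nothing else changed, the series now has a direct comparison at this place on the ring, para to a large group. In this assay, the change from 4-nitrophenyl to phenyl gives an at least 3.8-fold higher number from compound 3 to compound 4 (0.58 log units; beyond the scatter), so among the compounds shown the readable number belongs to the nitro compound alone, and the bare phenyl ring does not keep it. The steps from compound 1 and from compound 2 to compound 4 join two limits and cannot be read, and the plain phenyl compound joins the 3-methoxyphenyl and 3-fluorophenyl compounds at the weak end of the series: the limit of > 10000 nM in this assay, at which 3 of the 4 values shown sit.

Compound 1 and compound 2 carry their groups at a different place from the nitro group of compound 3, so the compounds shown do not separate the effect of the group from that of its place, and a 3-nitrophenyl compound would bear on this. Going by these compounds, it also remains open whether a nitrile, a trifluoromethyl group or an amine in the place of the nitro group would give a readable number.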